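Dropping a Phenyl Group on Two Related Cores

The compounds below may be only part of what the source reports. "The series", "measured", "known", "first", "only" and "open" are said of these compounds alone.

Compound 1 `CC(C)(C)C1=CC(=O)C=C(NCc2ccccc2)C1=O` and compound 3 `CC(C)(C)C1=CC(=O)C(NCc2ccccc2)=CC1=O` are built from the same atoms joined differently; the difference between their two cores is not broken down here. In an ADME assay on HaCaT cells (Homo sapiens) for cytotoxicity, read by MTT assay, with a stated time of 72 h (a lower number here means a stronger inhibitor, a higher number a weaker inhibitor), compound 1 gives 21000 nM, while compound 3 gives 28000 nM, and these two numbers lie within the usual scatter of each other. Compound 2 `CNC1=CC(=O)C=C(C(C)(C)C)C1=O` arises from compound 1 by one change, (hydrogen in place of phenyl on a saturated chain carbon bound to an amine nitrogen). In this assay compound 2 gives 10000 nM, so the step is a 2.1-fold lower number from compound 1 to compound 2 (0.32 log units; beyond the scatter). Compound 4 `CNC1=CC(=O)C(C(C)(C)C)=CC1=O` arises from compound 3 by the same change, (hydrogen in place of phenyl on a saturated chain carbon bound to an amine nitrogen), at the same place. Because a 2.1-fold lower number from compound 1 to compound 2 (0.32 log units; beyond the scatter) was only modest, the expected step here is similar: a 2.2-fold lower number from compound 3 to compound 4 (0.33 log units; beyond the scatter). Compound 4 is therefore estimated at 13000 nM, with a likely range from 7000 nM to 26000 nM.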

Compound 4, half-maximal inhibitory concentration: 28000 nM
Compound 4: the middle estimate sits 2.2-fold (0.33 log units) below what was measured; the measured number lies above the stated range.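

In this assay, hydrogen in place of phenyl on a saturated chain carbon bound to an amine nitrogen gives no change at the digits printed from compound 3 to compound 4 (within the scatter). Set beside the same change on the other core, the two steps cannot be told apart: the same change on two cores in this assay, a 2.1-fold lower number (0.32 log units; beyond the scatter) from compound 1 to compound 2 and no change at the digits printed (within the scatter) from compound 3 to compound 4, 2.1-fold (0.32 log units) apart, within the scatter of two such steps. Among the compounds shown here, this fits a change that carries over between these two cores, but it does not prove that it does, since each core offers only one pair and only the step on the core of compound 1 lies beyond the scatter.

From the compounds shown here alone, only phenyl and hydrogen appear at this place, so what a carboxylic acid or a longer chain would give there remains open. Going by these compounds, how the change behaves on any further core also remains open.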